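A few compounds are considered here, and "the series" means these few. Any claim that something is new, unique, unknown or untested is made for them only; others in the source may bear on it.

Measured compounds:
- compound 1, `COc1cc2c(Oc3ccc(NC(=O)c4nn(-c5ccccc5)c(=O)cc4C)cc3F)ccnc2cc1OCCCN1CCCCC1`, a functional assay on NCI-H460 cells (Homo sapiens) for inhibition, read by MTT assay, with a stated time of 72 h; a lower number here means a stronger inhibitor, a higher number a weaker inhibitor: 280 nM
- compound 2, `COc1cc2c(Oc3ccc(NC(=O)c4nn(-c5ccccc5C)c(=O)cc4C)cc3F)ccnc2cc1OCCCN1CCCCC1`, this assay: 3220 nM
- compound 3, `COc1cc2c(Oc3ccc(NC(=O)c4nn(-c5cccc(F)c5)c(=O)cc4C)cc3F)ccnc2cc1OCCCN1CCCC1`, this assay: 280 nM

Compound 3 stands level with compound 1 at the digits printed, and together they give the lowest numbers of the three; compound 2 sits furthest away, with a 12-fold higher number from compound 1 to compound 2 (1.06 log units; beyond the scatter) when a methyl replaces a hydrogen on an aromatic carbon.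

Compound 4, `COc1cc2c(Oc3ccc(NC(=O)c4nn(-c5cccc(F)c5)c(=O)cc4C)cc3F)ccnc2cc1OCCCN1CCCCC1`, has not yet been measured. It differs from compound 3 in one place: piperidin-1-yl in place of pyrrolidin-1-yl on a saturated chain carbon, three bonds along the chain from an oxygen on an aromatic ring. For the measured compounds named here, none of the measured steps bears on this change; the only measured step concerns the aromatic methyl, not the saturated ring at the end of the chain. Compound 1 carries the piperidine ring that enters here, and compound 3 carries the pyrrolidine ring, yet they differ in a second place as well, so their matching numbers only hint that the ring change is mild. Compound 4 is therefore expected to show no change at the digits printed from compound 3 to compound 4 (within the scatter), no step beyond the scatter, with an estimate of 280 nM and a range from 120 nM to 650 nM.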

Compound 4, half-maximal inhibitory concentration: 360 nM
For compound 4 the middle estimate is 1.3-fold (0.11 log units) below the measured one; low and high end bracket the measured number.
By their numbers in this assay, from the lowest: compounds 1, 3 and 4 (each within the scatter of the next); then compound 2.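

In this assay, piperidin-1-yl in place of pyrrolidin-1-yl at the end of the chain gives a 1.3-fold higher number from compound 3 to compound 4 (0.11 log units; within the scatter) and so isolates the ring change. The earlier compounds shown here could only hint at this change. Compound 1 and compound 3 differ in two places. For the compounds shown here, compound 4 also allows two more single-place readings on the aromatic nitrogen's phenyl group: fluoro in place of hydrogen gives a 1.3-fold higher number from compound 1 to compound 4 (0.11 log units; within the scatter) and 3-fluorophenyl in place of 2-methylphenyl gives an 8.9-fold lower number from compound 2 to compound 4 (0.95 log units; beyond the scatter) as the only step here beyond the scatter besides the methyl step. Nothing on hand explains these numbers.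

Open, on these data alone, is whether morpholin-4-yl, dimethylamino or a longer chain would match the two saturated rings. Also open, as far as these compounds go, is whether the ring change reads the same with 2-methylphenyl on the nitrogen.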